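The source may hold more compounds than are shown below. What is called first, only, known or untested is meant among the compounds shown, and "the series" means these compounds.

Measured compounds:
- compound 1, `Cc1cc(NC(=O)Nc2ccc(C(=O)O)cc2)c2ccccc2n1`, 9300 nM
- compound 2, `Cc1cc(NC(=O)Nc2ccc(C(=O)O)c(O)c2)c2ccccc2n1`, 26600 nM
- compound 3, `Cc1cc(NC(=O)Nc2ccc(F)cc2F)c2ccccc2n1`, 3000 nM

In a physicochemical assay for solubility, at pH 7.4 (a lower number here means a less soluble compound, a higher number a more soluble compound), compound 1 stands second highest of the three numbers. Its nearest neighbour is compound 2, and the step of a 2.9-fold higher number from compound 1 to compound 2 (0.46 log units; beyond the scatter) is a modest one. Compound 3 sits furthest away, with a lower number than compound 1, a gap that lies beyond the scatter.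

The unmeasured compound 4, `Cc1cc(NC(=O)Nc2ccc(C(F)(F)F)cc2)c2ccccc2n1`, differs from compound 1 in one place: trifluoromethyl in place of carboxy on an aromatic carbon. Going by the values given here, the single measured step, from compound 1 to compound 2, concerns a hydroxy added on an aromatic carbon and does not touch the carboxy, so it bears only loosely on this change. What the data do offer is compound 3, which carries no carboxy on its aryl ring and gives 3000 nM, the lowest of the set. Compound 4 likewise loses the carboxy, so the step of a 6.2-fold lower number from compound 1 to compound 4 (0.79 log units; beyond the scatter) is expected to run downward, beyond the scatter.

Compound 4 is therefore estimated at 1500 nM in this assay, with a range from 400 nM to 5000 nM.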

Compound 4, solubility: 100 nM
Compound 4: the middle estimate sits 15-fold (1.18 log units) above what was measured; the whole stated range lies above it.
By their numbers in this assay, from the lowest: compound 4; then compound 3; then compound 1; then compound 2.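

In this assay, the step of a 93-fold lower number from compound 1 to compound 4 (1.97 log units; beyond the scatter) shows that the group on this aromatic carbon, para to a large group, can move the number a long way, much further than the hydroxy step a 2.9-fold higher number from compound 1 to compound 2 (0.46 log units; beyond the scatter) did. Going by these compounds alone, the earlier compounds held no direct exchange at this position, so this is the first pair in which only the group there changes, with the core of compound 1 left as it stands. The carboxy that leaves carries a hydrogen-bond donor and a hydrogen-bond acceptor and the trifluoromethyl that enters carries neither, but that count only describes the exchange, and nothing measured here accounts for the size of the step.

The compounds shown leave open where other groups at this position would fall, for instance an amine, a nitrile or a methyl ester, and so whether the number follows from losing the carboxy or from bringing in trifluoromethyl. They also leave open whether the hydroxy would raise the number on compound 4 as it does on compound 1.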